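A few compounds are considered here, and "the series" means these few. Any claim that something is new, unique, unknown or untested is made for them only; others in the source may bear on it.

Of the compounds shown here, three have been measured in a functional assay on NCI-H1299 cells (Homo sapiens) for cytotoxicity, read by resazurin assay, with a stated time of 72 h; on this read-out lower numbers stand for stronger inhibition and higher numbers for weaker inhibition. Compound 1 (`COc1cc(/C=C/C(=O)OCCCCCCO[N+](=O)[O-])ccc1O`) gives > 50000 nM, a limit of the assay and not a number. Compound 2 (`COc1cc(/C=C/C(=O)OCCCO[N+](=O)[O-])ccc1OCCCO[N+](=O)[O-]`) gives > 50000 nM, which is also only a limit. Compound 3 (`O=C(/C=C/c1ccc(OCCCCCCO[N+](=O)[O-])c(O)c1)OCCCCCCO[N+](=O)[O-]`) gives > 50000 nM, again only a limit. Compound 2 therefore has no numerical position in the series and stands with the other two at the limit of > 50000 nM in this assay, at which 3 of the 3 values shown sit.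

The step of interest leads to compound 4 (`COc1cc(/C=C/C(=O)OCCCO[N+](=O)[O-])ccc1O`). The change is hydrogen in place of 3-(nitrooxy)propyl on an oxygen on an aromatic ring. Among the measured compounds shown here, no measured pair shows this change directly, so the expectation rests on the limits alone. Compound 1 also carries hydroxy on that oxygen, and its result is the limit > 50000 nM. No step beyond the usual scatter is expected in this assay, in either direction, and the expected change is a number no higher from compound 2 to compound 4 (the limit leaves the size open). For compound 4 the estimated value is 50000 nM, with an expected range from 25000 nM to 100000 nM.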

Compound 4, half-maximal inhibitory concentration: 28300 nM
Beside the measured number, compound 4's estimate is 1.8-fold (0.25 log units) above it; the range from low to high includes it.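

Among the four compounds, only compound 4 gives a number rather than a limit in this assay, and it pairs hydroxy on the aromatic oxygen with the shorter 3-(nitrooxy)propyl chain. Hydrogen in place of 3-(nitrooxy)propyl on that oxygen gives an at least 1.7-fold lower number from compound 2 to compound 4 (0.24 log units; that floor lies within the scatter), while the change in the chain, with hydroxy kept on that oxygen, gives an at least 1.7-fold lower number from compound 1 to compound 4 (0.24 log units; that floor lies within the scatter). Both steps are floors only, and their true sizes stay open because the other compounds rest at a limit: the limit of > 50000 nM in this assay, at which 3 of the 4 values shown sit.

The compounds shown leave open whether a small group such as methyl on that oxygen would also give a number in this assay. They also leave open whether the nitrooxy group matters, which a plain propyl chain or a carboxylic acid in place of the chain could test.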